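A few compounds are considered here, and "the series" means these few. Any claim that something is new, unique, unknown or untested is made for them only; others in the source may bear on it.

Values in a functional assay on BXPC-3 cells (Homo sapiens) for inhibition, read by XTT assay, with a stated time of 72 h; a lower number here means a stronger inhibitor, a higher number a weaker inhibitor:
Compound 1 `Cc1ccc([S+]([O-])N2CCC[C@H]2COCCCCCCCCC/C=C/c2ccc(-c3ccccc3)cc2)cc1`: > 100000 nM, a limit of the assay, not a number.
Compound 2 `O=CN1CCC[C@H]1COCCCCCCCCC/C=C/c1ccc(-c2ccccc2)cc1`: 66700 nM
Compound 3 `CC(=O)N1CCC[C@H]1COCCCCCCCCC/C=C/c1ccc(-c2ccccc2)cc1`: 56700 nM

For the measured compounds named here, compound 3 cannot be separated from the only other actual number: a 1.2-fold lower number from compound 2 to compound 3 (0.07 log units; within the scatter). Compound 4 `CC(C)(C)OC(=O)NCC(=O)N1CCC[C@H]1COCCCCCCCCC/C=C/c1ccc(-c2ccccc2)cc1` differs from compound 3 by (tert-butoxycarbonyl)amino in place of hydrogen on a saturated chain carbon bound to a carbonyl carbon, with (tert-butoxycarbonyl)amino in place of hydrogen on a saturated chain carbon bound to a carbonyl carbon. The closest measured change is that same step, methyl in place of hydrogen on a carbonyl carbon. Replacing the whole group on the ring nitrogen gives only a floor: an at least 1.7-fold lower number from compound 1 to compound 3 (0.24 log units; that floor lies within the scatter). Neither step points to a clear shift in this assay, so no change beyond the scatter is expected. The estimated step is a 1.1-fold lower number from compound 3 to compound 4 (0.05 log units; within the scatter). Compound 4 is expected at 50000 nM, with an estimated range of 15000 nM to 100000 nM.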

Compound 4, half-maximal inhibitory concentration: > 100000 nM
Compound 4: only a limit was reported; the forecaster's own chance of this, stated with the estimate: 25%; at least 2.0-fold (0.30 log units) between middle value and limit.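

In this assay compound 4 gives > 100000 nM, a limit of the assay and not a number. The first group placed on this saturated chain carbon bound to a carbonyl carbon, (tert-butoxycarbonyl)amino, brings no lower number, but only floors can be read: an at least 1.7-fold higher number from compound 3 to compound 4 (0.24 log units; that floor lies within the scatter) and an at least 1.4-fold higher number from compound 2 to compound 4 (0.17 log units; that floor lies within the scatter), while the step involving compound 1 cannot be read. The size of any rise stays unknown because the readings stop at the same limit: the limit of > 100000 nM in this assay, at which 2 of the 4 values shown sit.

From the compounds shown here alone, whether a free amine at this carbon, or a longer chain on the carbonyl carbon, would give a lower number remains open.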